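From compound 2 to compound 3: a methoxy added

The source may hold more compounds than are shown below. What is called first, only, known or untested is meant among the compounds shown, and "the series" means these compounds.

Compound 1 `Cc1cccc(C)c1-c1cccc(COc2ccc(SCC(=O)O)cc2)c1`: 3.82
Compound 2 `Cc1cccc(C)c1-c1cccc(COc2ccc(S(=O)(=O)CC(=O)O)cc2)c1`: 2.49

In a physicochemical assay for lipophilicity, using the shake flask method, in phosphate buffer, measured as octanol-water partition, with a stated time of 24 h, at pH 7.4, tested at 100 uM (a higher number here means a more lipophilic compound, a lower number a more polar compound), compound 2 is the lower of the two measured compounds, at 2.49. Compound 3 `COc1cc(C)c(-c2cccc(COc3ccc(S(=O)(=O)CC(=O)O)cc3)c2)c(C)c1` differs from it by methoxy in place of hydrogen on an aromatic carbon. Among the measured compounds shown here, the only measured step, a number 1.33 log units lower from compound 1 to compound 2 (beyond the scatter), is large, but it replaces (carboxymethyl)sulfanyl with (carboxymethyl)sulfonyl at another place. For the measured compounds named here, no measured step therefore covers methoxy directly, and no change beyond the scatter is expected. The expected step is a number 0.11 log units higher from compound 2 to compound 3 (within the scatter). Compound 3 is estimated at 2.6, with an expected range from 2.25 to 2.95.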

Compound 3, distribution coefficient: 2.45
Beside the measured number, compound 3's estimate is 0.15 log units above it; measured number inside the range.
By their numbers in this assay, from the lowest: compounds 3 and 2 (each within the scatter of the next); then compound 1.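

In this assay, methoxy in place of hydrogen on the aromatic carbon para to a large group gives a number 0.04 log units lower from compound 2 to compound 3 (within the scatter). Among the compounds shown here, this is the first reading at this position, and 2,6-dimethylphenyl to 4-methoxy-2,6-dimethylphenyl does not separate the two compounds, unlike the change at the other place, a number 1.33 log units lower from compound 1 to compound 2 (beyond the scatter). No measurement offers an explanation for this result. Going by these compounds, whether an amine or a longer alkoxy chain at this position would also stay within the scatter remains open, as does whether methoxy would give the same step on compound 1.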